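This account rests on a few compounds, and the source may have more. Where it says the series, first, only, none or still open, it means among the compounds named here.

Measured so far in a functional assay on the whole organism for inhibition, with Rattus norvegicus as the target, read by cytopathic effect and paw edema, at a dose of 100 mg/kg by the oral route; a lower number here means less inhibition, a higher number more inhibition at the dose given (going by the name of the read-out):
compound 1, `Cc1ccc(NC(=O)c2c(O)c3cccnc3n(-c3ccccc3)c2=O)cc1`, gives 2.2%
compound 2, `O=C(Nc1cnccn1)c1c(O)c2cccnc2n(-c2ccccc2)c1=O`, gives 21.2%
compound 3, `O=C(NCc1cccnc1)c1c(O)c2cccnc2n(-c2ccccc2)c1=O`, gives 14.7%

Compound 3 holds the second highest of the three numbers: its difference from compound 2, a number 6.5 percentage points lower from compound 2 to compound 3 (within the scatter), is within the scatter, while its rise over compound 1, a number 12.5 percentage points higher from compound 1 to compound 3 (beyond the scatter), is beyond it. Compound 4, `O=C(NCc1ccncc1)c1c(O)c2cccnc2n(-c2ccccc2)c1=O`, carries one change against compound 3: pyridin-4-yl in place of pyridin-3-yl on a saturated chain carbon bound to an amide-type nitrogen. Among the measured compounds shown here, no measured step moves a ring nitrogen in this way, so none bears on it directly; the nearest comparison, a swap of the whole group on the amide nitrogen between compound 2 and compound 3, stayed within the scatter. The step from compound 3 to compound 4 is therefore expected to be small, a number 0.3 percentage points higher from compound 3 to compound 4 (within the scatter), with no clear direction. Compound 4 is estimated at 15%, between 5% and 28%.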

Compound 4, a percentage reported as inhibition, in the whole organism at one dose (the size of the read-out at that dose, not a potency): 15.4%
Compound 4: the middle estimate sits 0.4 percentage points below what was measured; the measured number falls inside the stated range.
By their numbers in this assay, from the lowest: compound 1; then compounds 3, 4 and 2 (each within the scatter of the next).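

In this assay, pyridin-4-yl and pyridin-3-yl on a saturated chain carbon bound to an amide-type nitrogen cannot be told apart (a number 0.7 percentage points higher from compound 3 to compound 4 (within the scatter)), so placing the ring nitrogen differently in this group has no visible effect here. The (pyridin-4-yl)methyl group also stays level with pyrazin-2-yl (a number 5.8 percentage points lower from compound 2 to compound 4 (within the scatter)) and, like (pyridin-3-yl)methyl, stands clear of 4-methylphenyl (a number 13.2 percentage points higher from compound 1 to compound 4 (beyond the scatter)). Nothing available explains these numbers. Still open, as far as these compounds go, is whether pyridin-2-yl on the same chain carbon, or a (pyridin-4-yl)ethyl group in place of (pyridin-4-yl)methyl, would read differently.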